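The source may hold more compounds than are shown below. What is called first, only, known or untested is meant among the compounds shown, and "the series" means these compounds.

Measured so far in a functional assay on MDA-MB-231 cells (Homo sapiens) for antiproliferative activity, read by MTT assay, with a stated time of 24 h; a higher number here means a weaker inhibitor, a lower number a stronger inhibitor:

compound 1, `COc1cc(-c2cc(C(=O)/C=C/c3ccc(Cl)cc3)nc3cc(-c4ccccc4)nn23)cc(OC)c1OC`: 21600 nM
compound 2, `COc1cc(-c2cc(/C=C/C(=O)c3ccc(Cl)cc3)nc3cc(-c4ccccc4)nn23)cc(OC)c1OC`: 32500 nM

Compound 2 has the higher of the two numbers in this assay, with compound 1 nearest; the step of a 1.5-fold higher number from compound 1 to compound 2 (0.18 log units; within the scatter) lies within the scatter, so the two values cannot be ordered.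

The next compound, compound 3, is `COc1ccc(C(=O)/C=C/c2cc(-c3cc(OC)c(OC)c(OC)c3)n3nc(-c4ccccc4)cc3n2)cc1`. It differs from compound 2 in one place:
methoxy in place of chloro on an aromatic carbon

Among the compounds with values here, no measured step bears on this change. Within the data shown here, the single step in hand, a 1.5-fold higher number from compound 1 to compound 2 (0.18 log units; within the scatter), concerns a different part of the molecule, and no pair of compounds in hand differs by a methoxy in place of a chloro. The reference point is therefore compound 2 alone, and the expectation is a step no larger than the scatter in either direction.

Compound 3 is estimated at 30000 nM in this assay, with a range of 10000 nM to 90000 nM. The expected step from compound 2 is a 1.1-fold lower number from compound 2 to compound 3 (0.03 log units; within the scatter).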

Compound 3, half-maximal inhibitory concentration: 13200 nM
The estimate for compound 3 lay 2.3-fold (0.36 log units) above the measured number, within the range that was stated.
By their numbers in this assay, from the lowest: compounds 3, 1 and 2 (each within the scatter of the next, the first and the last beyond it).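

In this assay, the position para to a large group on the six-membered aromatic ring responds to substitution: methoxy in place of chloro gives a 2.5-fold lower number from compound 2 to compound 3 (0.39 log units; beyond the scatter), a modest step but the first in the series to lie beyond the scatter. With 2-((4-methoxyphenyl)carbonyl)ethenyl in place of (2-(4-chlorophenyl)ethenyl)carbonyl, the change is a 1.6-fold lower number from compound 1 to compound 3 (0.21 log units; within the scatter), which leaves those two compounds unordered. Nothing in hand accounts for the step from chloro to methoxy.

Going by these compounds, this reading rests on a single pair, so it remains open whether the same change would give a similar step with the (2-(4-chlorophenyl)ethenyl)carbonyl linkage of compound 1. On these data alone, it also remains open how an amine, a hydroxyl or a longer chain such as ethoxy would behave at this position.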